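The source may report more compounds than this note shows. Statements on the series, on what has been measured and on what is new or still open speak of the compounds shown alone.

Compound 1 `COc1cc2nc(N3CCC(OCCOc4ccccc4)CC3)nc(N)c2cc1OC` gives 0.48 nM in an assay on brain for displacement of a labelled ligand from Adrenergic receptor alpha-1 (Rattus norvegicus) (a lower number here means a stronger inhibitor, a higher number a weaker inhibitor), the lowest of the two numbers measured; its nearest neighbour, compound 2 `COc1cc2nc(N3CCC(OCC(C)(C)O)CC3)nc(N)c2cc1OC`, gives 1.28 nM. Going by the values given here, the one measured step, a 2.7-fold higher number from compound 1 to compound 2 (0.43 log units; beyond the scatter), is modest. Compound 3 `COc1cc2nc(N3CCC(OCC(C)(O)c4ccccc4)CC3)nc(N)c2cc1OC` differs from compound 1 by 1-hydroxy-1-phenylethyl in place of phenoxymethyl on a saturated chain carbon bound to an oxygen on a saturated carbon. The step from compound 1 to compound 2 bears on this, since both changes introduce a hydroxyl at the same place, but compound 3 keeps the aromatic ring that compound 2 lacks. A small weakening, if any, is therefore expected, of about a 1.7-fold higher number from compound 1 to compound 3 (0.22 log units; within the scatter). Compound 3 is estimated at 0.8 nM, within 0.3 nM to 2.5 nM.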

Compound 3, inhibition constant: 0.62 nM
Compound 3: middle estimate off by 1.3-fold (0.11 log units), on the high side; the measured number falls inside the stated range.
By their numbers in this assay, from the lowest: compounds 1 and 3 (each within the scatter of the next); then compound 2.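

In this assay, 1-hydroxy-1-phenylethyl in place of phenoxymethyl gives a 1.3-fold higher number from compound 1 to compound 3 (0.11 log units; within the scatter), so at this position a hydroxyl and an aromatic ring can stand together without a shift beyond the scatter. With the hydroxyl kept, phenyl in place of methyl gives a 2.1-fold lower number from compound 2 to compound 3 (0.31 log units; beyond the scatter), a modest step tied to the aromatic ring. No measured evidence gives a cause for either step. The compounds shown do not isolate the contribution of the hydroxyl itself. Also open, on these data alone, is how an amine or a carboxylic acid in its place, or a longer chain carrying the phenyl, would read in this assay.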